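A few compounds are considered here, and "the series" means these few. Any claim that something is new, unique, unknown or untested is made for them only; others in the source may bear on it.

Measured so far in a functional assay on PANC-1 cells (Homo sapiens) for cytotoxicity, read by MTT assay, with a stated time of 72 h; on this read-out lower numbers stand for stronger inhibition and higher numbers for weaker inhibition:

Compound 1 `COc1cc(NC2=CC(=O)c3ncncc3C2=O)cc(OC)c1` gives 7200 nM.
Compound 2 `O=C1C(Nc2ccc(CO)cc2)=CC(=O)c2ncncc21` gives 1000 nM.
Compound 3 `COc1cccc(NC2=CC(=O)c3ncncc3C2=O)c1` gives 600 nM.

Compound 3 carries the lowest number of the three in this assay, but compound 2 lies within the usual scatter of it, so the two cannot be ranked against each other; only compound 1 stands clearly apart, as the step of a 12-fold lower number from compound 1 to compound 3 (1.08 log units; beyond the scatter) shows, a large change for the loss of one methoxy group.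

Compound 4 `O=C1C(Nc2cccc(B(O)O)c2)=CC(=O)c2ncncc21` is the next compound, and it differs from compound 3 in one place: a group of 3 heavy atoms (1 boron, 2 oxygen; no ring) in place of a group of 2 heavy atoms (1 carbon, 1 oxygen; no ring), on an aromatic carbon. This is a swap on the same aromatic ring that the measured step touched, yet it is a different kind of change, since a group is exchanged rather than removed. Among the measured compounds shown here, none of the measured steps is of this kind, so the single step from compound 1 to compound 3 offers only indirect guidance: it says that the ring tolerates change at this place and that such change can move the number a long way, but not in which direction an exchange would go.

For the measured compounds named here, the estimate for compound 4 in this assay is therefore a modest step, a 2.5-fold higher number from compound 3 to compound 4 (0.40 log units; beyond the scatter), with the wide range that follows from having no closely matching precedent. Compound 4 is expected to give about 1500 nM, between 400 nM and 6000 nM.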

Compound 4, half-maximal inhibitory concentration: 9000 nM
For compound 4 the middle estimate is 6.0-fold (0.78 log units) below the measured one; measured number above the stated range.
By their numbers in this assay, from the lowest: compounds 3 and 2 (each within the scatter of the next); then compounds 1 and 4 (each within the scatter of the next).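

In this assay, exchanging the methoxy on this aromatic carbon for the boron-bearing group gives a 15-fold higher number from compound 3 to compound 4 (1.18 log units; beyond the scatter), so a swap at this one place can cost as much as a change elsewhere on the ring. The earlier step, a 12-fold lower number from compound 1 to compound 3 (1.08 log units; beyond the scatter), showed only that taking a methoxy away can lower the number; this new step shows that an exchange on the same ring can raise it sharply, and compound 3 has the lower number in both steps. Nothing measured here accounts for the rise, and it cannot be told whether it follows from the loss of the methoxy or from the arrival of the new group.

On these data alone, it remains open whether a plain hydrogen, an amine or a carboxylic acid on this carbon would keep the number close to that of compound 3 or push it up as in compound 4. Also open, as far as these compounds go, is whether the boron-bearing group would have the same effect at another place on the ring.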